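This account rests on a few compounds, and the source may have more. Where it says the series, first, only, none or still open, it means among the compounds named here.

Four related compounds are described here. Compound 1 (`CN(C)CCCNC(=O)c1cc(NC(=O)c2cc(NC(=O)c3cc(NC(=N)N)cn3C)cn2C)cn1C`) and compound 2 (`COc1cccc(C(=N)Nc2cc(C(=O)Nc3cc(C(=O)Nc4cc(C(=O)NCCCN(C)C)n(C)c4)n(C)c3)n(C)c2)c1`) share a chain of linked amide units. In an ADME assay on HEK293 cells (Homo sapiens) for cytotoxicity, read by fluorescence and resazurin assay, with a stated time of 20 h (on this read-out higher numbers stand for lower toxicity in this test and lower numbers for higher toxicity in this test), compound 1 gives "not determined" (no result reported), and in this assay compound 2 gives "not determined" (no result reported), so neither of them contributes a number. Compound 3 (`CC(C)CCc1sc(NC(=O)c2cc(NC(=O)c3cc(NC(=N)c4cnc5ccccc5c4)cn3C)cn2C)nc1C(=O)NCCCN(C)C`) carries the same kind of chain, extended by a sulfur-containing ring, and in this assay compound 3 gives 1.2 ug/mL. Within the data shown here, this is the only number available, so compound 3 cannot be placed above or below any neighbour; it simply sets the starting point.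

Compound 4 (`CC(C)CCc1sc(NC(=O)c2cc(NC(=O)c3cc(NC(=N)c4ccccc4)cn3C)cn2C)nc1C(=O)NCCCN(C)C`) differs from compound 3 in one spot: phenyl in place of quinolin-3-yl on a carbon with a double bond to nitrogen. A larger two-ring group is replaced by a smaller single ring, and nothing else in the molecule moves. Among the measured compounds shown here, no pair of measured compounds shows a comparable exchange, so there is no recorded step to lean on.

On that basis the step from compound 3 to compound 4 is expected to be small, at most a shift of a 1.5-fold higher number from compound 3 to compound 4 (0.18 log units; within the scatter) toward lower toxicity, and quite possibly nothing beyond the usual scatter. Compound 4 is therefore estimated at 1.8 ug/mL in this assay, within a range of 0.7 ug/mL to 5 ug/mL.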

Compound 4, half-maximal cytotoxic concentration: > 32 ug/mL
Compound 4: a limit, no number (the forecaster's own chance of this, stated with the estimate: 10%); middle value at least 17-fold (1.24 log units) away from the limit.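

The position on a carbon with a double bond to nitrogen now proves able to change the read-out strongly, which the lone number for compound 3 could not show. With phenyl in place of quinolin-3-yl, this assay gives an at least 26-fold higher number from compound 3 to compound 4 (1.42 log units; beyond the scatter), a large move toward lower toxicity in this test from one exchange. Quinolin-3-yl has a carbon-only ring and a ring with a hetero atom, while phenyl has only the carbon-only ring, so this single pair cannot say which of these differences matters, and the reading for compound 4 is a limit of the assay and not a number: the limit of > 32 ug/mL in this assay, at which 1 of the 4 values shown sits.

A group such as pyridin-3-yl, a single ring containing nitrogen, or naphthalen-2-yl, two rings of carbon only, would help separate ring size from the ring nitrogen, but neither is among the compounds shown. From the compounds shown here alone, how far the true value of compound 4 lies from its limit, and whether the same exchange acts alike on a different core, also remain open.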